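Expected stability of a new carbonyl substituent

The compounds below may be only part of what the source reports. "The series", "measured", "known", "first", "only" and "open" are said of these compounds alone.

Compound 1 `CN1CCC(CNS(=O)(=O)c2ccccc2Nc2cc(-c3ccc4ccn(C)c4c3)c3nccnc3c2)C1` with 0.633 h
Compound 2 `Cn1cc(CNS(=O)(=O)c2ccccc2Nc2cc(-c3ccc4ccn(C)c4c3)c3nccnc3c2)cn1` with 0.267 h
Compound 3 `CN(C)C(=O)c1ccncc1Nc1cc(-c2ccc3ccn(C)c3c2)c2nccnc2c1` with 0.35 h

These values come from an ADME assay on microsomes from liver (Mus musculus, strain CD-1) for metabolic stability, read by LC-MS, tested at 2 uM (a higher number here means that the compound lasts longer, a lower number that the compound disappears faster), and place compound 3 within the scatter of both compound 1 and compound 2. Compound 4 `CN1CCC(NC(=O)c2ccncc2Nc2cc(-c3ccc4ccn(C)c4c3)c3nccnc3c2)CC1=O` differs from compound 3 by having (1-methyl-2-oxopiperidin-4-yl)amino in place of dimethylamino on a carbonyl carbon. Going by the values given here, only one measured step is available, a 2.4-fold lower number from compound 1 to compound 2 (0.37 log units; beyond the scatter), which is modest but beyond the scatter. It exchanges 1-methylpyrrolidin-3-yl for 1-methyl-1H-pyrazol-4-yl on a saturated chain carbon bound to a sulfonamide nitrogen, so it bears only loosely on a change at the carbonyl carbon. Among the compounds with values here, no measured step shows a direction for this change, and therefore no shift beyond the scatter is expected in this assay. The estimated step is a 1.1-fold higher number from compound 3 to compound 4 (0.06 log units; within the scatter), which would stay within the scatter. For compound 4 the expected value is 0.4 h, with an estimated range from 0.17 h to 0.9 h.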

Compound 4, half-life: 0.717 h
The estimate for compound 4 lay 1.8-fold (0.25 log units) below the measured number; the range from low to high includes it.
By their numbers in this assay, from the lowest: compounds 2, 3, 1 and 4 (each within the scatter of the next, the first and the last beyond it).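

In this assay, the carbonyl carbon now has a measured step of its own: (1-methyl-2-oxopiperidin-4-yl)amino in place of dimethylamino gives a 2.0-fold higher number from compound 3 to compound 4 (0.31 log units; beyond the scatter). The step is modest, but it shows that this much larger group, with its six-membered non-aromatic ring and its hydrogen-bond donor, is accepted at this place without a lower number. No available evidence accounts for the change.

The compounds shown do not separate the parts of the entering group, so the step cannot be assigned to the ring, the ring carbonyl, the methyl on the ring nitrogen or the amide hydrogen. On these data alone, it also remains open whether (1-methylpiperidin-4-yl)amino, which lacks the ring carbonyl, or simple methylamino on the same carbonyl carbon would give a similar number.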